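The compounds below may be only part of what the source reports. "The series", "measured", "known", "first", "only" and "open" are said of these compounds alone.

Compound 1 `O=C(/C=C/C(=O)N1C/C(=C\c2ccccc2)C(=O)/C(=C/c2ccccc2)C1)Nc1ccc([N+](=O)[O-])cc1` gives 40000 nM in a functional assay on L1210 cells (Mus musculus) for cytotoxicity; on this read-out higher numbers stand for weaker inhibition and lower numbers for stronger inhibition.
Compound 2 `CC(=O)c1ccc(NC(=O)/C=C/C(=O)N2C/C(=C\c3ccc([N+](=O)[O-])cc3)C(=O)/C(=C/c3ccc([N+](=O)[O-])cc3)C2)cc1` gives 1400 nM in this assay.
Compound 3 `O=C(/C=C/C(=O)N1C/C(=C\c2ccc([N+](=O)[O-])cc2)C(=O)/C(=C/c2ccc([N+](=O)[O-])cc2)C1)Nc1ccc([N+](=O)[O-])cc1` gives 1000 nM in this assay.

Among these three, compound 1 stands at the highest number; compound 2 and compound 3, which both carry nitro groups on the two arylidene rings of the shared core, sit at clearly lower numbers, and each of those gaps lies beyond the scatter. No single-point change connects compound 1 to either of them.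

Compound 4 `COc1ccc(NC(=O)/C=C/C(=O)N2C/C(=C\c3ccccc3)C(=O)/C(=C/c3ccccc3)C2)cc1` is compound 1 with methoxy in place of nitro on an aromatic carbon. Among the compounds with values here, the one measured step that bears on this position is the exchange on the anilide aryl between compound 2 and compound 3: a 1.4-fold lower number from compound 2 to compound 3 (0.15 log units; within the scatter). That step says a swap of the group on this ring, at least between acetyl and nitro, leaves the number essentially where it was. On that basis, and with nothing else to go on, the change from compound 1 to compound 4 is expected to stay close to no change, with a step of no change at the digits printed from compound 1 to compound 4 (within the scatter). Compound 4 is therefore estimated at 40000 nM, with a range from 15000 nM to 110000 nM.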

Compound 4, half-maximal inhibitory concentration: 6800 nM
The estimate for compound 4 lay 5.9-fold (0.77 log units) above the measured number, outside the stated range (below it).
By their numbers in this assay, from the lowest: compounds 3 and 2 (each within the scatter of the next); then compound 4; then compound 1.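

In this assay the exchange of nitro for methoxy on an aromatic carbon para to a large group is a 5.9-fold lower number from compound 1 to compound 4 (0.77 log units; beyond the scatter) and so shows that the group at this place can shift the number beyond the scatter, toward stronger inhibition. The earlier exchange at this place, a 1.4-fold lower number from compound 2 to compound 3 (0.15 log units; within the scatter) and did not show this, but it replaced acetyl with nitro and was read with nitro on both arylidene rings, whereas the new step is read on the core of compound 1 with no such nitro groups. No measurement in hand explains the size or direction of the new step.

As far as these compounds go, it remains open whether methoxy in place of nitro would give a similar step with nitro on both arylidene rings, as in compound 3, or whether the effect of this exchange depends on those rings. From the compounds shown here alone, it is also open how other groups at this place would compare with methoxy and nitro, for example an amine, a carboxylic acid or a longer alkoxy chain.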